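Compound 3 to compound 4: changing the aryl group

A few compounds are considered here, and "the series" means these few. Any claim that something is new, unique, unknown or untested is made for them only; others in the source may bear on it.

- compound 1 `O=C1NC(=O)c2ccc(-n3cccc3)cc2/C1=C/Nc1ccc(CN2CCCCC2)cc1` gives 2100 nM
- compound 2 `O=C1NC(=O)c2ccc(-c3ccoc3)cc2/C1=C/Nc1ccc(CN2CCCCC2)cc1` gives 1100 nM
- compound 3 `O=C1NC(=O)c2ccc(-c3ccsc3)cc2/C1=C/Nc1ccc(CN2CCCCC2)cc1` gives 3400 nM

In a functional assay on MCF7 cells (Homo sapiens) for antiproliferative activity, read by sulforhodamine B assay (on this read-out higher numbers stand for weaker inhibition and lower numbers for stronger inhibition), compound 3 gives 3400 nM as the highest of the three numbers, although only compound 2 lies beyond the scatter from it. Going by the values given here, compound 4 `O=C1NC(=O)c2ccc(-c3cccc(O)c3)cc2/C1=C/Nc1ccc(CN2CCCCC2)cc1` carries 3-hydroxyphenyl in place of thiophen-3-yl on an aromatic carbon as its one change. The measured steps are small: a 3.1-fold higher number from compound 2 to compound 3 (0.49 log units; beyond the scatter) is modest, while a 1.9-fold lower number from compound 1 to compound 2 (0.28 log units; within the scatter) and a 1.6-fold higher number from compound 1 to compound 3 (0.21 log units; within the scatter) stay within the scatter. Among the compounds with values here, no measured compound carries 3-hydroxyphenyl, so these steps guide size only. The estimated change is a 1.7-fold lower number from compound 3 to compound 4 (0.23 log units; within the scatter) in this assay and no step beyond the scatter is expected. Compound 4 is expected at 2000 nM (estimated range 700 nM to 5500 nM).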

Compound 4, half-maximal inhibitory concentration: 2000 nM
Compound 4: the middle estimate sits on the measured number at the digits printed, and the stated range covers the measured number.
By their numbers in this assay, from the lowest: compounds 2, 4, 1 and 3 (each within the scatter of the next, the first and the last beyond it).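

In this assay a six-membered aromatic ring of carbon only, carrying a hydroxy group, can stand on this aromatic carbon in place of the five-membered aromatic rings without any step beyond the scatter. Thus a 1.7-fold lower number from compound 3 to compound 4 (0.23 log units; within the scatter) and a 1.8-fold higher number from compound 2 to compound 4 (0.26 log units; within the scatter) and a 1.1-fold lower number from compound 1 to compound 4 (0.02 log units; within the scatter) all stay within it, so this ring size and added hydrogen-bond donor show no separate effect here. No measurement at hand bears on a cause for these steps.

Left open is what plain phenyl would give here, and so whether the hydroxy group matters at all. Also open, as far as these compounds go, is how an aminomethyl group or a carboxylic acid on the same ring would read.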